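The source may report more compounds than this note shows. Statements on the series, on what has been measured and on what is new or still open speak of the compounds shown alone.

Series so far, in an ADME assay on HEK293 cells (Homo sapiens) for cytotoxicity, read by MTT assay, with a stated time of 48 h; a higher number here means a weaker inhibitor, a lower number a stronger inhibitor:
- compound 1 `Cc1nc(-c2ccc(Cl)cc2)sc1C(=O)CSc1nc(-c2ccccc2)c(C#N)c(=O)[nH]1` gives "not determined" (no result reported)
- compound 2 `COc1ccc(-c2nc(C)c(C(=O)CSc3nc(-c4ccc(Cl)cc4)c(C#N)c(=O)[nH]3)s2)cc1` gives 63000 nM

Among the compounds with values here, compound 2 carries the only number, so it cannot be ranked against anything. Compound 1 offers no comparison. The next compound to be tested is compound 3 `COc1ccc(-c2nc(C)c(C(=O)CSc3nc(-c4ccc(OC)c(OC)c4)c(C#N)c(=O)[nH]3)s2)cc1`, which has 3,4-dimethoxyphenyl in place of 4-chlorophenyl on an aromatic carbon, ortho to a cyano group: 3,4-dimethoxyphenyl in place of 4-chlorophenyl on an aromatic carbon. The rest of the structure is unchanged. Within the data shown here, no step between measured compounds exists to show how this position behaves, and compound 2 at 63000 nM is the sole anchor. No direction can be argued from these data. The expected step is a 1.1-fold lower number from compound 2 to compound 3 (0.02 log units; within the scatter), and nothing beyond the usual scatter is expected. The estimated value for compound 3 is 60000 nM, with an expected range of 20000 nM to 160000 nM.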

Compound 3, half-maximal inhibitory concentration: 23300 nM
The estimate for compound 3 lay 2.6-fold (0.41 log units) above the measured number, within the range that was stated.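

In this assay, within the data shown here, the aryl group on the aromatic carbon ortho to a cyano group affects the read-out: 3,4-dimethoxyphenyl in place of 4-chlorophenyl gives a 2.7-fold lower number from compound 2 to compound 3 (0.43 log units; beyond the scatter) as the first readable step. This single modest step shows that the position is not silent, but chlorine leaves and two methoxy groups enter in the same exchange, so the step cannot be assigned to either part of it. No measurement at hand bears on the origin of the step.

Among these compounds, compound 1 has no number, so no step involving it can be read. On these data alone, it remains open whether a single methoxy group, or an amine or a carboxylic acid on that phenyl ring, would move the value further in either direction.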